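Ethoxy removal on a curcumin-like scaffold: a second test

A few compounds are considered here, and "the series" means these few. Any claim that something is new, unique, unknown or untested is made for them only; others in the source may bear on it.

The series consists of three measured compounds and one awaiting measurement. Compound 1 `CCOc1cc(C=C(C(=O)/C=C/c2ccc(O)c(OC)c2)C(=O)/C=C/c2ccc(O)c(OC)c2)ccc1O` gives 3980 nM in a functional assay, read by spectrophotometry, with a stated time of 5 min; a lower number here means a stronger inhibitor, a higher number a weaker inhibitor. Compound 2 `COc1cc(/C=C/C(=O)C(=Cc2ccc(O)cc2)C(=O)/C=C/c2ccc(O)c(OC)c2)ccc1O` gives 6320 nM in this assay. Compound 3 `CCOc1cc(C=C(C(=O)/C=C/c2ccc(O)c(OCC)c2)C(=O)/C=C/c2ccc(O)c(OCC)c2)ccc1O` gives 5140 nM in this assay, and compound 4 `CCOc1cc(/C=C/C(=O)C(=Cc2ccc(O)cc2)C(=O)/C=C/c2ccc(O)c(OCC)c2)ccc1O` is the unmeasured member.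

The change from compound 1 to compound 2 is hydrogen in place of ethoxy on an aromatic carbon. It produced a 1.6-fold higher number from compound 1 to compound 2 (0.20 log units; within the scatter). The same change is now made on a different core: from compound 3 to compound 4 the difference is hydrogen in place of ethoxy on an aromatic carbon. The difference between the two cores, compound 1 against compound 3, is not broken down here.

Since the surroundings of the change are the same in both pairs, and since the first step lay within the scatter, the expectation for compound 4 rests on the step recorded from compound 1 to compound 2 together with the value of compound 3. Compound 4 is therefore estimated to show a 1.5-fold higher number from compound 3 to compound 4 (0.16 log units; within the scatter) in this assay, a step that, like the earlier one, may well fall within the scatter. On that basis the value expected for compound 4 in this assay is 7500 nM, with a likely range from 4000 nM to 14000 nM.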

Compound 4, half-maximal inhibitory concentration: 14800 nM
Estimate against measurement, compound 4: 2.0-fold (0.30 log units) below; the measured number lies above the stated range.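

In this assay, putting hydrogen in place of ethoxy gives a 2.9-fold higher number from compound 3 to compound 4 (0.46 log units; beyond the scatter) and so, on this second core, turning 3-ethoxy-4-hydroxyphenyl into 4-hydroxyphenyl goes with a weaker inhibitor. Set beside the earlier step, the change moves the number the same way on both cores, and the size of the two steps cannot be told apart, even though only the second step lies beyond the scatter: the same change on two cores in this assay, a 1.6-fold higher number (0.20 log units; within the scatter) from compound 1 to compound 2 and a 2.9-fold higher number (0.46 log units; beyond the scatter) from compound 3 to compound 4, 1.8-fold (0.26 log units) apart, within the scatter of two such steps. This supports carrying the change from one core to the other in direction and, as far as two pairs can show, in size, but it does not show that the step is larger on the core of compound 3, that it would hold on a third core, or why the number rises at all.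

The compounds shown compare only ethoxy and hydrogen at this place, so they leave open how a longer chain such as propoxy, an amine or a carboxylic acid would read there on either core. They also leave open whether the step would keep its direction if the ethoxy group still present on the other ring of compound 4 were changed as well.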